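The source may hold more compounds than are shown below. What is called first, only, known or untested is meant among the compounds shown, and "the series" means these compounds.

In a functional assay on A549 cells (Homo sapiens) for antiproliferative activity, read by MTT assay, with a stated time of 24 h (a higher number here means a weaker inhibitor, a lower number a stronger inhibitor), compound 1 `O=C(NNc1cccc(Cl)c1)c1cccc(NS(=O)(=O)c2cnc(O)nc2O)c1` gives 6640 nM, compound 2 `O=C(NNc1ccccc1F)c1cccc(NS(=O)(=O)c2cnc(O)nc2O)c1` gives 11100 nM, and compound 3 `O=C(NNc1ccccc1F)c1ccccc1NS(=O)(=O)c1cnc(O)nc1O` gives 9610 nM. Repeated measurements of this kind naturally vary, and compound 2 lies within that usual scatter of both compound 1 and compound 3. On these numbers, it has no clear separation from either.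

The next structure is compound 4 `O=C(NNC(=O)c1ccccc1Cl)c1cccc(NS(=O)(=O)c2cnc(O)nc2O)c1`, which differs from compound 2 in one place: (2-chlorophenyl)carbonyl in place of 2-fluorophenyl on an amine nitrogen. Put simply, (2-chlorophenyl)carbonyl stands in place of 2-fluorophenyl on an amine nitrogen. The group that enters still holds an aromatic ring, but it also brings a carbonyl.

Going by the values given here, one measured step bears on this change. At the same nitrogen, 2-fluorophenyl replaced 3-chlorophenyl in a 1.7-fold higher number from compound 1 to compound 2 (0.22 log units; within the scatter), a change small enough to stay within the scatter. Among the compounds with values here, that comparison only swaps one ring group for another, however, and no measured compound has a carbonyl at this place. It is therefore weak evidence, and the range has to stay wide.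

In this assay, the expected change is a 1.1-fold lower number from compound 2 to compound 4 (0.05 log units; within the scatter), which would not go beyond the scatter. The estimated value for compound 4 is 10000 nM, with an expected range from 4000 nM to 25000 nM.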

Compound 4, half-maximal inhibitory concentration: 3740 nM
For compound 4 the middle estimate is 2.7-fold (0.43 log units) above the measured one, outside the stated range (below it).
By their numbers in this assay, from the lowest: compounds 4, 1, 3 and 2 (each within the scatter of the next, the first and the last beyond it).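

In this assay, going by these compounds alone, (2-chlorophenyl)carbonyl in place of 2-fluorophenyl on the amine nitrogen gives a 3.0-fold lower number from compound 2 to compound 4 (0.47 log units; beyond the scatter), the first step at this place that goes beyond the usual scatter, though only modestly. Set against the 3-chlorophenyl group at the same place, the new group gives a 1.8-fold lower number from compound 1 to compound 4 (0.25 log units; within the scatter), which stays within the scatter, so compound 4 separates clearly from compound 2 but not from compound 1. This shows that a carbonyl can stand on this nitrogen with the antiproliferative activity kept, but no measurement available here explains the step with compound 2.

Compound 4 differs from compound 2 in both the carbonyl and the halogen on the ring. The compounds shown cannot divide the step between these two features, and (2-fluorophenyl)carbonyl at the same place would be needed to do so. As far as these compounds go, it also remains open whether the aromatic ring is needed once the carbonyl is present, a question that a small acetyl group on this nitrogen could address.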